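Swapping an aromatic ring for cyclohexyl in compound 2

The source may hold more compounds than are shown below. What is called first, only, known or untested is meant among the compounds shown, and "the series" means these compounds.

In an ADME assay on microsomes from liver (Mus musculus) for metabolic stability, with a stated time of 10 min (on this read-out higher numbers stand for a more stable compound and lower numbers for a less stable compound), compound 1 `CC(=O)N1CCN(C(=O)N2CC[C@](c3ccc(C(OCc4c(F)cccc4C#N)(C(F)(F)F)C(F)(F)F)cc3)(S(=O)(=O)c3ccc(F)cc3)C2)CC1` gives 1%, while compound 2 `Cc1cccc(F)c1COC(c1ccc([C@]2(S(=O)(=O)c3ccc(F)cc3)CCN(C(=O)[C@H]3CC[C@H](C(=O)O)CC3)C2)cc1)(C(F)(F)F)C(F)(F)F` gives 78%, the higher of the two and well beyond the scatter. These two compounds differ in more than one place, so their gap cannot be tied to any single group. Compound 3 `O=C(O)[C@H]1CC[C@H](C(=O)N2CC[C@](c3ccc(C(OCC4CCCCC4)(C(F)(F)F)C(F)(F)F)cc3)(S(=O)(=O)c3ccc(F)cc3)C2)CC1` differs from compound 2 in one place only: cyclohexyl in place of 2-fluoro-6-methylphenyl on a saturated chain carbon bound to an oxygen on a saturated carbon. Put simply, 2-fluoro-6-methylbenzyl becomes cyclohexylmethyl, so a six-membered aromatic ring gives way to a non-aromatic one. Within the data shown here, no measured step shows what this swap does, so any forecast is loose. Compound 2 has far more room to fall than to rise from 78%, which points towards a moderate loss. The expected change is a number 23 percentage points lower from compound 2 to compound 3 (beyond the scatter), a fall beyond the scatter. For compound 3, the estimated value is 55%, with an expected range of 25% to 80%.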

Compound 3, percent of the compound remaining: 78%
Estimate against measurement, compound 3: 23 percentage points below, within the range that was stated.
By their numbers in this assay, from the lowest: compound 1; then compounds 2 and 3 (each within the scatter of the next).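

In this assay, replacing the aromatic ring with a non-aromatic one gives no change at the digits printed from compound 2 to compound 3 (within the scatter). This single pair therefore shows that, on a saturated chain carbon bound to an oxygen on a saturated carbon, cyclohexyl and 2-fluoro-6-methylphenyl cannot be told apart on this read-out, something the earlier pair, which differs in more than one place, could not show. Nothing available here explains why the two rings read alike.

From the compounds shown here alone, it remains open whether a ring is needed in this place at all, or whether an open hexyl chain, a pyridine ring or a cyclohexyl ring carrying an amine would read the same. Going by these compounds, it is also open whether the same swap would leave the read-out unchanged on the core of compound 1.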